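The source may hold more compounds than are shown below. What is called first, only, known or untested is meant among the compounds shown, and "the series" means these compounds.

Three compounds share one core and differ only in the aryl group on the ring nitrogen. In a functional assay on CHO cells with adenosine receptor A1 (Homo sapiens) as the target, read by cAMP accumulation and immunoassay, with a stated time of 6 min, tested at 0.1 uM (a lower number here means a stronger effect, a higher number a weaker effect of the compound at the concentration tested), compound 1 `Nc1scc(CN2CCN(c3ccc(F)cc3Cl)CC2)c1C(=O)c1ccc(Cl)cc1` gives -6.2%, compound 2 `Nc1scc(CN2CCN(c3cccnc3)CC2)c1C(=O)c1ccc(Cl)cc1` gives 3.4%, and compound 3 `Nc1scc(CN2CCN(c3ccc(F)cc3F)CC2)c1C(=O)c1ccc(Cl)cc1` gives -17%, the lowest of the three numbers. The step from compound 1 to compound 3 was a number 10.8 percentage points lower from compound 1 to compound 3 (beyond the scatter), and that from compound 2 to compound 3 was a number 20.4 percentage points lower from compound 2 to compound 3 (beyond the scatter). Compound 4 `Nc1scc(CN2CCN(c3ccccc3Cl)CC2)c1C(=O)c1ccc(Cl)cc1` carries 2-chlorophenyl in place of 2,4-difluorophenyl on an amine nitrogen in a ring. This reverses the fluoro-for-chloro exchange seen in compound 1, so a modest rise back toward the number of compound 1 is expected, giving an estimated step of a number 11 percentage points higher from compound 3 to compound 4 (beyond the scatter). For compound 4 the estimated value in this assay is therefore -6%, within a range of -20% to 8%.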

Compound 4, a percentage reported as activity, at one concentration (the size of the read-out at that concentration, not a potency): 2%
Beside the measured number, compound 4's estimate is 8 percentage points below it; the measured number falls inside the stated range.
By their numbers in this assay, from the lowest: compound 3; then compounds 1, 4 and 2 (each within the scatter of the next).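

At this position on the ring nitrogen, 2-chlorophenyl separates clearly only from 2,4-difluorophenyl, with a number 19 percentage points higher from compound 3 to compound 4 (beyond the scatter) in this assay. Removing the fluoro from the 2-chloro-4-fluorophenyl group gives a number 8.2 percentage points higher from compound 1 to compound 4 (within the scatter), and exchanging pyridin-3-yl for 2-chlorophenyl gives a number 1.4 percentage points lower from compound 2 to compound 4 (within the scatter), so neither change separates the compounds, and only the 2,4-difluorophenyl compound stands apart among the four. No measurement offered here explains why this group differs. From the compounds shown here alone, how an aryl group carrying methoxy or trifluoromethyl would read remains open. Going by these compounds, whether compound 3 keeps its separation at other concentrations also remains open.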